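Aryl change at the carbonyl carbon of the shared core

The source may hold more compounds than are shown below. What is called first, only, known or untested is meant among the compounds shown, and "the series" means these compounds.

The three measured compounds share one core, seen in compound 1 `CNC(=O)c1cc(Oc2ccc3nc(NC(=O)Nc4ccc(Cl)cc4Cl)sc3c2)ccn1`, compound 2 `CNC(=O)c1cc(Oc2ccc3nc(NC(=O)Nc4ccc(Br)cc4)sc3c2)ccn1` and compound 3 `CNC(=O)c1cc(Oc2ccc3nc(NC(=O)Nc4cc(C(F)(F)F)cc(C(F)(F)F)c4)sc3c2)ccn1`; they differ only in the aryl group joined to the carbonyl carbon through the amide-type nitrogen. In a functional assay on HCT-116 cells (Homo sapiens) for inhibition, read by MTT assay, with a stated time of 2 days, tested at 100 uM (on this read-out higher numbers stand for more inhibition of growth at the one concentration tested and lower numbers for less inhibition of growth), compound 1 gives 93.6% and compound 3 gives 98.4%, while compound 2 gives 80%, the lowest of the three numbers, beyond the scatter from both of the others. Among the measured compounds shown here, the one single-point step, a number 13.6 percentage points lower from compound 1 to compound 2 (beyond the scatter), shows that the halogen pattern alone moves the number by a modest amount.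

Compound 4 `CNC(=O)c1cc(Oc2ccc3nc(NC(=O)c4ccc(Cl)cc4)sc3c2)ccn1` differs from compound 2 in one place: 4-chlorophenyl in place of (4-bromophenyl)amino on a carbonyl carbon. For the measured compounds named here, the measured step bears on this only loosely, as it alters the ring substituents and keeps the amide-type nitrogen; no measured pair speaks to dropping that nitrogen from the link to the carbonyl carbon. Since every measured compound inhibits strongly at the single concentration, a still high number is expected for compound 4, with wide uncertainty. The step of a number 8 percentage points lower from compound 2 to compound 4 (within the scatter) is expected to lie within the scatter or somewhat downward. Compound 4 is estimated at 72%, ranging from 45% to 92%.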

Compound 4, percent growth inhibition at one concentration: 80.5%
The estimate for compound 4 lay 8.5 percentage points below the measured number; measured number inside the range.
By their numbers in this assay, from the lowest: compounds 2 and 4 (each within the scatter of the next); then compounds 1 and 3 (each within the scatter of the next).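

In this assay, the amide-type nitrogen in the link to the carbonyl carbon can go without a change beyond the scatter when 4-chlorophenyl takes the place of (4-bromophenyl)amino, giving a number 0.5 percentage points higher from compound 2 to compound 4 (within the scatter). Against the (2,4-dichlorophenyl)amino group the same kind of replacement gives a number 13.1 percentage points lower from compound 1 to compound 4 (beyond the scatter), so at this position the outcome depends on which aryl group is being replaced, and the halogen changes along with the link in both pairs. No measurement shown here offers an explanation for either step.

The compounds shown do not separate loss of the nitrogen from the change of halogen, which a 4-bromophenyl group directly on the carbonyl carbon would do. From the compounds shown here alone, how a benzylamino group or a piperidine ring at this carbonyl carbon would read also remains open.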